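Halogen swap carried from one indole core to the other

The compounds below may be only part of what the source reports. "The series", "measured", "known", "first", "only" and "open" are said of these compounds alone.

Compound 1 `O=C(O)/C(S)=C/c1c[nH]c2cc(Br)ccc12` and compound 2 `O=C(O)/C(S)=C/c1c[nH]c2cc(Cl)ccc12` share a core and differ in one place: chloro in place of bromo on an aromatic carbon In an assay on isolated protein for inhibition of Calpain-1 catalytic subunit (Sus scrofa), read by FRET (a higher number here means a weaker inhibitor, a lower number a stronger inhibitor), compound 1 gives 7 nM and compound 2 gives 210 nM, a step of a 30-fold higher number from compound 1 to compound 2 (1.48 log units; beyond the scatter). Compound 3 `O=C(O)/C(S)=C/c1c[nH]c2ccc(Br)cc12` has the same atoms as compound 1, joined differently; the difference between the two cores is not broken down here. In this assay compound 3 gives 6 nM, within the scatter of compound 1. Compound 4 `O=C(O)/C(S)=C/c1c[nH]c2ccc(Cl)cc12` differs from compound 3 in one place: chloro in place of bromo on an aromatic carbon This is the same change that separates compound 1 from compound 2, now made on the core of compound 3. Within the data shown here, the expected step is a 25-fold higher number from compound 3 to compound 4 (1.40 log units; beyond the scatter) because the single measured instance of this change gave a 30-fold higher number from compound 1 to compound 2 (1.48 log units; beyond the scatter), with the caveat that one instance on one core may not transfer fully. The estimate for compound 4 in this assay is 150 nM, within a range from 30 nM to 600 nM.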

Compound 4, half-maximal inhibitory concentration: 250 nM
Beside the measured number, compound 4's estimate is 1.7-fold (0.22 log units) below it, and the stated range covers the measured number.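

In this assay, chloro in place of bromo on an aromatic carbon gives a 42-fold higher number from compound 3 to compound 4 (1.62 log units; beyond the scatter). Set beside the earlier step, the change carries from one core to the other with no difference in size: the same change on two cores in this assay, a 30-fold higher number (1.48 log units; beyond the scatter) from compound 1 to compound 2 and a 42-fold higher number (1.62 log units; beyond the scatter) from compound 3 to compound 4, 1.4-fold (0.14 log units) apart, within the scatter of two such steps. Among these compounds, this rests on only two pairs in a single assay, so it gives no reason for the size of the step and no reading for any third core.

Left open is how iodo, methyl or a nitrile on the same aromatic carbon would compare with bromo and chloro. Also open, going by these compounds, is whether the step would hold on either core with an amide in place of the carboxylic acid.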